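The source may hold more compounds than are shown below. What is called first, only, known or untested is meant among the compounds shown, and "the series" means these compounds.

Compound 1 `CCCCCCCCNc1nc(SCc2ccc(C(F)(F)F)cc2)nc2ccccc12` in a functional assay on MDA-MB-231 cells (Homo sapiens) for cytotoxicity, read by MTT assay, with a stated time of 72 h (a higher number here means a weaker inhibitor, a lower number a stronger inhibitor), gives 22300 nM. Compound 2 `FC(F)(F)c1ccc(CSc2nc(N3CCCCC3)c3ccccc3n2)cc1` gives 28400 nM. Compound 3 `FC(F)(F)c1ccc(CSc2nc(Nc3ccccc3Cl)c3ccccc3n2)cc1` gives only > 50000 nM, which is a limit of the assay and not a number.

Compound 3 thus sits at the limit of > 50000 nM in this assay, at which 1 of the 3 values shown sits, beyond the scatter from compound 1 by an at least 2.2-fold higher number from compound 1 to compound 3 (0.35 log units; beyond the scatter), whereas an at least 1.7-fold higher number from compound 2 to compound 3 (0.24 log units; that floor lies within the scatter). Compound 4 `COc1ccccc1Nc1nc(SCc2ccc(C(F)(F)F)cc2)nc2ccccc12` differs from compound 3 by methoxy in place of chloro on an aromatic carbon. Within the data shown here, no measured step exchanges one substituent for another on this phenyl ring; the only steps that bear on compound 4 are the two leading into compound 3, both toward weaker inhibition. Compound 4 is therefore expected to stay near the limit, with no step beyond the scatter, estimated at 55000 nM (20000 nM to 150000 nM), a step that the limit leaves unreadable from compound 3 to compound 4.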

Compound 4, half-maximal inhibitory concentration: > 50000 nM
Compound 4: a limit, no number; the forecaster's own chance of this, stated with the estimate: 60%; the middle value lies beyond the limit too.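

In this assay compound 4 gives only a limit of the assay, > 50000 nM, and not a number. With (2-methoxyphenyl)amino on the shared core, the change from octylamino gives an at least 2.2-fold higher number from compound 1 to compound 4 (0.35 log units; beyond the scatter), and the change from piperidin-1-yl gives an at least 1.7-fold higher number from compound 2 to compound 4 (0.24 log units; that floor lies within the scatter). The step between compound 3 and compound 4 cannot be read, so methoxy and chloro on this phenyl ring cannot be ranked, and the limit now holds both: the limit of > 50000 nM in this assay, at which 2 of the 4 values shown sit.

Left open is whether a different group at this place, such as a hydroxyl or an amine, would bring the value back within the range of the assay. Also open, going by these compounds, is how a chain longer than octyl on the nitrogen would compare with compound 1.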